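The source may hold more compounds than are shown below. What is called first, only, known or untested is meant among the compounds shown, and "the series" means these compounds.

In a functional assay on PC-3 cells (Homo sapiens) for antiproliferative activity, read by sulforhodamine B assay (on this read-out lower numbers stand for stronger inhibition and higher numbers for weaker inhibition), compound 2, `CCCCCCCCCCCCCCCCCCNC(=O)[C@@H]1CSC(c2ccc(OC)cc2)N1`, gives 19000 nM, the highest of the two numbers recorded so far. Its nearest neighbour is compound 1, `CCCCCCCCCCCCCCCCCCNC(=O)[C@@H]1CSC(c2cccc(O)c2)N1`, which gives 6700 nM. For the measured compounds named here, the only step measured to date is a 2.8-fold higher number from compound 1 to compound 2 (0.45 log units; beyond the scatter), a change of one substituted phenyl for another on the same saturated ring carbon. Compound 3, `CCCCCCCCCCCCCCCCCCNC(=O)[C@@H]1CSC(c2cc(OC)c(OC)c(OC)c2)N1`, has not been measured. It differs from compound 2 by 3,4,5-trimethoxyphenyl in place of 4-methoxyphenyl on a saturated ring carbon. Going by the values given here, no measured step alters this phenyl in the same way, so the single recorded step, a modest rise when a methoxy-bearing phenyl entered, is the only guide and a weak one. On that basis the step of a 1.1-fold higher number from compound 2 to compound 3 (0.02 log units; within the scatter) is expected to be small and not clearly beyond the scatter, if anything slightly upward. Compound 3 is therefore estimated at 20000 nM in this assay, within a range from 6000 nM to 60000 nM.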

Compound 3, half-maximal inhibitory concentration: 4000 nM
Estimate against measurement, compound 3: 5.0-fold (0.70 log units) above, outside the stated range (below it).
By their numbers in this assay, from the lowest: compounds 3 and 1 (each within the scatter of the next); then compound 2.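

In this assay, the group on this saturated ring carbon also proved able to bring the number down: 3,4,5-trimethoxyphenyl in place of 4-methoxyphenyl gives a 4.8-fold lower number from compound 2 to compound 3 (0.68 log units; beyond the scatter) and shows that a methoxy-bearing phenyl does not in itself go with the higher number. Set against the 3-hydroxyphenyl group, the same 3,4,5-trimethoxyphenyl group gives a 1.7-fold lower number from compound 1 to compound 3 (0.22 log units; within the scatter) and so cannot be told apart from it here, which leaves compound 2 alone at the high end of the three. Nothing available explains this difference between the substituted phenyl groups.

The compounds shown leave open how an unsubstituted phenyl, or a phenyl bearing an amine or a carboxylic acid, would compare at this carbon. They also leave open whether the numbers would hold with a shorter chain on the amide.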